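Growth inhibition notes: from compound 3 to compound 4

The compounds below may be only part of what the source reports. "The series", "measured", "known", "first", "only" and "open" are said of these compounds alone.

- compound 1 `Cc1cccc(Nc2ncnc3ccc(NC(=S)NCc4ccccc4)cc23)c1`: 19500 nM
- compound 2 `S=C(NCc1ccccc1)Nc1ccc2ncnc(Nc3ccc(-c4ccccc4)cc3)c2c1`: 8400 nM
- compound 3 `Oc1ccc(NC(=S)Nc2ccc3ncnc(Nc4cccc(Br)c4)c3c2)cc1`: 17300 nM

All three values come from a functional assay on MDA-MB-231 cells (Homo sapiens) for inhibition, read by MTT assay, with a stated time of 48 h; a higher number here means a weaker inhibitor of growth, a lower number a stronger inhibitor of growth. The number for compound 3 lies within the scatter of compound 1 and above that of compound 2, with the latter gap beyond the scatter. In compound 4 `S=C(Nc1ccc(Br)cc1)Nc1ccc2ncnc(Nc3cccc(Br)c3)c2c1` the change is bromo in place of hydroxy on an aromatic carbon, para to a large group. Among the measured compounds shown here, no measured pair shows this change, so the expectation rests only on the narrow spread of the three values. A small move toward a lower number, not beyond the scatter, is expected, an estimated 1.6-fold lower number from compound 3 to compound 4 (0.20 log units; within the scatter). The estimate for compound 4 is 11000 nM, with an expected range of 4500 nM to 25000 nM.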

Compound 4, concentration for 50% growth inhibition: > 30000 nM
Compound 4 gave a limit, no number; the forecaster's own chance of this, stated with the estimate: 5%; at least 2.7-fold (0.43 log units) between middle value and limit.
By their numbers in this assay, from the lowest: compound 2; then compounds 3 and 1 (each within the scatter of the next). At a limit, above all of these: compound 4.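

In this assay compound 4 gives a limit and not a number: > 30000 nM. Among the compounds shown, this is the only comparison at this position, and 4-hydroxyphenyl to 4-bromophenyl gives an at least 1.7-fold higher number from compound 3 to compound 4 (0.23 log units; that floor lies within the scatter), so bromo in place of hydroxy brings no lower number here, though the floor of the step alone does not separate the two compounds. The true size of the step cannot be read: the limit of > 30000 nM in this assay, at which 1 of the 4 values shown sits.

Open, as far as these compounds go, is how an amine or a carboxylic acid at this position would read, and whether either would give a number rather than a limit.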